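Cytotoxicity notes on a trifluoromethyl benzimidazole series

This account rests on a few compounds, and the source may have more. Where it says the series, first, only, none or still open, it means among the compounds named here.

Measured so far in an ADME assay on BHK cells (Mesocricetus auratus) for cytotoxicity, read by MTT assay, with a stated time of 96 h; on this read-out higher numbers stand for lower toxicity in this test and lower numbers for higher toxicity in this test:
- compound 1 `CCC(=O)Nc1ccc(-c2nc3cc(C(F)(F)F)ccc3[nH]2)cc1` gives 100000 nM
- compound 2 `CCC(=O)Nc1ccc(-c2nc3cc(C(F)(F)F)ccc3n2C)cc1` gives a limit of the assay, > 100000 nM
- compound 3 `Cn1c(-c2ccc(NC(=O)CN3CCN(c4ccccc4)CC3)cc2)nc2cc(C(F)(F)F)ccc21` gives 100000 nM

Compound 2 differs from compound 1 by hydrogen in place of methyl on an aromatic nitrogen, and the step is a number no higher from compound 2 to compound 1 (the limit leaves the size open); its size is not readable due to the limit of > 100000 nM in this assay, at which 1 of the 3 values shown sits. The cores of compound 2 and compound 3 differ by 4-phenylpiperazin-1-yl in place of methyl on a saturated chain carbon bound to a carbonyl carbon, with the step of a number no higher from compound 2 to compound 3 (the limit leaves the size open), again of open size. Compound 3 and compound 1 sit level in this assay within the scatter.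

Compound 4 `O=C(CN1CCN(c2ccccc2)CC1)Nc1ccc(-c2nc3cc(C(F)(F)F)ccc3[nH]2)cc1` is not yet measured. It differs from compound 3 by hydrogen in place of methyl on an aromatic nitrogen, the same change as that between compound 2 and compound 1. Since compound 1 and compound 3 both sit at the value of compound 1, 100000 nM, the expected step is no change at the digits printed from compound 3 to compound 4 (within the scatter), within the scatter. Compound 4 is estimated at 100000 nM in this assay, between 50000 nM and 200000 nM.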

Compound 4, half-maximal cytotoxic concentration: > 100000 nM
Compound 4: a limit, no number; the forecaster's own chance of this, stated with the estimate: 40%; the middle value lies on the limit itself.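

In this assay compound 4 gives a limit, not a number, so neither step for hydrogen in place of methyl on an aromatic nitrogen can be read in size. Set side by side with the step on the other core, the step of a number no lower from compound 3 to compound 4 (the limit leaves the size open) can be compared in direction only: the same change on two cores in this assay, a number no higher (the limit leaves the size open) from compound 2 to compound 1 and a number no lower (the limit leaves the size open) from compound 3 to compound 4; the limit leaves it open whether they differ. This does not show that the change carries from one core to the other with the same size, nor that it fails to carry, and much of the set offers no readable number: the limit of > 100000 nM in this assay, at which 2 of the 4 values shown sit.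

The compounds shown leave open what an ethyl group would give on that aromatic nitrogen. They also leave open what a smaller amine such as morpholine would give in place of 4-phenylpiperazin-1-yl on the chain.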